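The source may report more compounds than this note shows. Statements on the series, on what has been measured and on what is new or still open speak of the compounds shown alone.

Measured so far in an ADME assay on MT4 cells (Homo sapiens) for cytotoxicity, read by MTT assay; on this read-out higher numbers stand for lower toxicity in this test and lower numbers for higher toxicity in this test:
compound 1 `CCS(=O)(=O)N1CCN(Cc2ccc(Nc3nccc(Oc4c(C)cc(/C=C/C#N)cc4C)n3)cc2)CC1` gives 4600 nM;
compound 2 `CCS(=O)(=O)N1CCN(Cc2ccc(Nc3nccc(Oc4c(C)cc(C#N)cc4C)n3)cc2)CC1` gives 5240 nM;
compound 3 `Cc1cc(C#N)cc(C)c1Oc1ccnc(Nc2ccc(CN3CCN(S(=O)(=O)C(C)C)CC3)cc2)n1` gives 4540 nM.

Compound 2 and compound 1 differ by 2-cyanoethenyl in place of cyano on an aromatic carbon, and this change made a step of a 1.1-fold lower number from compound 2 to compound 1 (0.06 log units; within the scatter). Compound 3 rests on a different core: it differs from compound 2 by methyl in place of hydrogen on a saturated chain carbon bound to a saturated chain carbon and a sulfonyl sulfur, and in this assay the two values of compound 2 and compound 3 lie within the scatter of each other. Compound 4 `Cc1cc(/C=C/C#N)cc(C)c1Oc1ccnc(Nc2ccc(CN3CCN(S(=O)(=O)C(C)C)CC3)cc2)n1` has not yet been measured. Within the data shown here, it differs from compound 3 by 2-cyanoethenyl in place of cyano on an aromatic carbon, the same change as the one between compound 2 and compound 1, at the same place. For compound 4 the expected step is a 1.1-fold lower number from compound 3 to compound 4 (0.05 log units; within the scatter), resting on the earlier step of a 1.1-fold lower number from compound 2 to compound 1 (0.06 log units; within the scatter), which stayed within the scatter. Compound 4 is therefore estimated to give about 4000 nM, expected to fall between 2000 nM and 8000 nM.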

Compound 4, half-maximal cytotoxic concentration: 3810 nM
The estimate for compound 4 lay 1.0-fold (0.02 log units) above the measured number, and the stated range covers the measured number.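

In this assay, among these compounds, putting 2-cyanoethenyl in place of cyano gives a 1.2-fold lower number from compound 3 to compound 4 (0.08 log units; within the scatter), and this agrees with the earlier step: the same change on two cores in this assay, a 1.1-fold lower number (0.06 log units; within the scatter) from compound 2 to compound 1 and a 1.2-fold lower number (0.08 log units; within the scatter) from compound 3 to compound 4, 1.0-fold (0.02 log units) apart, within the scatter of two such steps Putting methyl in place of hydrogen on the chain carbon bound to the sulfonyl sulfur gives a 1.2-fold lower number from compound 1 to compound 4 (0.08 log units; within the scatter), which agrees in the same way: the same change on two cores in this assay, a 1.2-fold lower number (0.06 log units; within the scatter) from compound 2 to compound 3 and a 1.2-fold lower number (0.08 log units; within the scatter) from compound 1 to compound 4, 1.0-fold (0.02 log units) apart, within the scatter of two such steps Each change thus reads alike on these two cores, but every step lies within the scatter, so this shows only that neither change visibly moves the number here, not that a larger effect would carry over or that other cores would behave alike.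

Still open, on these data alone, is whether an amine or a carboxylic acid on that aromatic carbon would shift the number beyond the scatter. The same question stands for a longer chain on the sulfonyl sulfur.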